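Series notes: substituent on the benzoxazole carbon and enzyme inhibition

This account rests on a few compounds, and the source may have more. Where it says the series, first, only, none or still open, it means among the compounds named here.

Measured so far:
compound 1 `Cn1ccc2cc(-c3ccc4oc(Cc5ccccc5)nc4c3)ccc21` 488 nM
compound 2 `Cn1ccc2cc(-c3ccc4oc(Nc5ccccn5)nc4c3)ccc21` 186 nM
compound 3 `Cn1ccc2cc(-c3ccc4oc(N5CCc6ccccc6C5)nc4c3)ccc21` 55 nM

In an assay on HEK293 cells for inhibition of Fatty-acid amide hydrolase 1 (Homo sapiens), read by fluorescence (on this read-out lower numbers stand for stronger inhibition and higher numbers for weaker inhibition), compound 2 gives 186 nM, the second highest number of the three; compound 1 gives 488 nM and compound 3 gives 55 nM. For the measured compounds named here, the one measured step, a 2.6-fold lower number from compound 1 to compound 2 (0.42 log units; beyond the scatter), changes a different group from the one altered here and so bears only loosely on the present question. From compound 2 to compound 4 `Cn1ccc2cc(-c3ccc4oc(N5Cc6cccnc6C5)nc4c3)ccc21` the change is a group of 9 heavy atoms (7 carbon, 2 nitrogen; one five-membered non-aromatic ring with 1 hetero atom, one six-membered aromatic ring with 1 hetero atom) in place of a group of 7 heavy atoms (5 carbon, 2 nitrogen; one six-membered aromatic ring with 1 hetero atom), on an aromatic carbon. Going by the values given here, no measured step covers this exchange; the nearest guide is compound 3, whose cyclic amine at the same place gives 55 nM. A modest lowering of the number is therefore expected: a 1.7-fold lower number from compound 2 to compound 4 (0.23 log units; within the scatter). Compound 4 is estimated at 110 nM in this assay, with a range of 40 nM to 300 nM.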

Compound 4, half-maximal inhibitory concentration: 211 nM
Estimate against measurement, compound 4: 1.9-fold (0.28 log units) below; measured number inside the range.
By their numbers in this assay, from the lowest: compound 3; then compounds 2 and 4 (each within the scatter of the next); then compound 1.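

In this assay, replacing (pyridin-2-yl)amino with the cyclic amine, which takes the group from 1 hydrogen-bond donor to 0, gives a 1.1-fold higher number from compound 2 to compound 4 (0.05 log units; within the scatter), so the donor count at this aromatic carbon does not separate the two compounds. A cyclic amine here is not enough to match compound 3 at 55 nM, although against the benzyl group it gives a 2.3-fold lower number from compound 1 to compound 4 (0.36 log units; beyond the scatter). No data are at hand to explain the gap between the two cyclic amines.

The carbon-only isoindoline would separate the ring nitrogen from ring size. As far as these compounds go, whether morpholine or piperidine at this carbon reaches the number of compound 3 remains open.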